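The source may hold more compounds than are shown below. What is called first, only, known or untested is meant among the compounds shown, and "the series" means these compounds.

Among the measured compounds shown here, compound 1 `COC(=O)Cc1c[nH]c(=O)c2ccc(Br)n12` is the only compound in this set with a definite number in a functional assay on PC-3 cells (Homo sapiens) for cytotoxicity, read by CCK-8 assay, with a stated time of 72 h; a higher number here means a weaker inhibitor, a lower number a stronger inhibitor: compound 1 gives 176000 nM. Compound 2 `COC(=O)Cc1c[nH]c(=O)c2cc(Br)c(Br)n12` carries a second bromo on an aromatic carbon, and in this assay compound 2 reaches only a limit of the assay, > 200000 nM, not a number. The step of an at least 1.1-fold higher number from compound 1 to compound 2 (0.05 log units; that floor lies within the scatter) therefore rests on that limit (the limit of > 200000 nM in this assay, at which 1 of the 2 values shown sits), and its floor lies within the scatter. Compound 3 `COC(=O)Cc1c[nH]c(=O)c2cccn12` has not been measured in this assay; it differs from compound 1 by hydrogen in place of bromo on an aromatic carbon. For the measured compounds named here, the only measured step that bears on this change runs the other way, adding bromo, and it showed at least a small shift towards a higher number; since the change to compound 3 removes bromo from the shared core, a shift towards a lower number, if any, is expected, though it need not exceed the scatter. Compound 3 is estimated to give 150000 nM in this assay, with a range from 60000 nM to 400000 nM. This estimate means an expected step of a 1.2-fold lower number from compound 1 to compound 3 (0.07 log units; within the scatter).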

Compound 3, half-maximal inhibitory concentration: > 200000 nM
Compound 3 ended at the assay's limit (the forecaster's own chance of this, stated with the estimate: 35%); at least 1.3-fold (0.12 log units) between middle value and limit.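

In this assay, hydrogen in place of bromo on an aromatic carbon, next to the ring nitrogen, gives an at least 1.1-fold higher number from compound 1 to compound 3 (0.05 log units; that floor lies within the scatter), which points the same way as the earlier step, an at least 1.1-fold higher number from compound 1 to compound 2 (0.05 log units; that floor lies within the scatter), made by adding a second bromo. Taking this bromo away and adding another thus both leave the definite number of compound 1 behind, so the earlier step does not set up a trend running with the number of bromo groups, and neither floor lies beyond the scatter. Compound 1 alone keeps a definite number, while the other two compounds stop at a limit of the assay, not at a number: the limit of > 200000 nM in this assay, at which 2 of the 3 values shown sit.

From the compounds shown here alone, how large the contribution of this bromo is, or whether it has any, stays open, as the two limits give only floors and no size for either change. Also open, going by these compounds, is how a chloro group or an amine on this aromatic carbon, or a carboxylic acid in place of the ester, would read in this assay.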